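The source may hold more compounds than are shown below. What is called first, only, known or untested is meant among the compounds shown, and "the series" means these compounds.

In a functional assay on HCT-116 cells (Homo sapiens) for antiproliferative activity, read by MTT assay, with a stated time of 72 h (on this read-out higher numbers stand for weaker inhibition and lower numbers for stronger inhibition), compound 1 `COc1cccc(N2C(=O)COc3ccc(-c4cnc(OC)c(NS(=O)(=O)c5ccc(F)cc5)c4)cc32)c1` reports only a limit, > 40000 nM, so it stands at the limit of > 40000 nM in this assay, at which 1 of the 3 values shown sits. Compound 2 `COc1cccc(N2C(=O)COc3ccc(-c4ccc(O)cc4)cc32)c1`, which keeps the 3-methoxyphenyl, gives 15300 nM, and compound 3 `O=C1COc2ccc(-c3cnc(Cl)c(NS(=O)(=O)c4ccc(F)cc4)c3)cc2N1C1CC1`, which lacks it, gives 12400 nM. Compound 4 `COc1ncc(-c2ccc3c(c2)N(C(C)C)C(=O)CO3)cc1NS(=O)(=O)c1ccc(F)cc1` carries isopropyl in place of 3-methoxyphenyl on an amide-type nitrogen in a ring. Among the compounds with values here, no measured pair shows this change alone. Since compound 3 gives 12400 nM without the 3-methoxyphenyl, a moderate gain in inhibition is expected in this assay, although compound 2 gives 15300 nM with that group in place. The expected step is an at least 2.2-fold lower number from compound 1 to compound 4 (0.34 log units; beyond the scatter). For compound 4 the estimate is 18000 nM, with an expected range of 6000 nM to 40000 nM.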

Compound 4, half-maximal inhibitory concentration: 19200 nM
The estimate for compound 4 lay 1.1-fold (0.03 log units) below the measured number, within the range that was stated.
By their numbers in this assay, from the lowest: compounds 3, 2 and 4 (each within the scatter of the next). At a limit, above all of these: compound 1.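

In this assay, within the data shown here, isopropyl in place of 3-methoxyphenyl on an amide-type nitrogen in a ring gives an at least 2.0-fold lower number from compound 1 to compound 4 (0.31 log units; beyond the scatter), the only change at this position that can be read alone. The position therefore gives up the six-membered aromatic ring with no loss of inhibition on this read-out. Compound 1 stands at a limit, so the step gives only a lower bound on the size of the change: the limit of > 40000 nM in this assay, at which 1 of the 4 values shown sits.

The compounds shown leave open whether methyl, benzyl or a longer chain on this nitrogen would go the same way as isopropyl.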